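Replacing the chain end of compound 3

The compounds below may be only part of what the source reports. "The series", "measured", "known", "first", "only" and "open" are said of these compounds alone.

Of the compounds shown here, three sharing one core have been measured so far in an ADME assay on microsomes from liver (Homo sapiens) for metabolic stability, read by LC-MS, tested at 1 uM; a higher number here means faster removal of the compound, a lower number slower removal. Compound 1 (`O=S(=O)(c1ccc([C@H]2CC[C@]3(CC2)OOC2(O3)C3CC4CC(C3)CC2C4)cc1)N1CCNCC1`) gives 16 mL.min-1.g-1 there, compound 2 (`CC(C)(O)CNCCCOc1ccc([C@H]2CC[C@]3(CC2)OOC2(O3)C3CC4CC(C3)CC2C4)cc1`) gives 8 mL.min-1.g-1 and compound 3 (`CS(=O)(=O)N1CCN(CCCOc2ccc([C@H]3CC[C@]4(CC3)OOC3(O4)C4CC5CC(C4)CC3C5)cc2)CC1`) gives 68 mL.min-1.g-1 as the highest of the three numbers, which makes compound 3 the one removed fastest.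

In compound 4 (`O[C@H]1CC[C@H](NCCCOc2ccc([C@H]3CC[C@]4(CC3)OOC3(O4)C4CC5CC(C4)CC3C5)cc2)CC1`), (4-hydroxycyclohexyl)amino stands in place of 4-(methylsulfonyl)piperazin-1-yl on a saturated chain carbon, three bonds along the chain from an oxygen on an aromatic ring ((4-hydroxycyclohexyl)amino in place of 4-(methylsulfonyl)piperazin-1-yl on a saturated chain carbon, three bonds along the chain from an oxygen on an aromatic ring).

The most relevant measurement is an 8.5-fold higher number from compound 2 to compound 3 (0.93 log units; beyond the scatter) at that same place, where the group that compound 4 loses replaced (2-hydroxy-2-methylpropyl)amino. Compound 4 also carries a hydroxy-bearing amino group, so that step, read backwards, is the best guide. However, no measured compound shows how the carbon ring of the entering group behaves. The other step, a 2.0-fold lower number from compound 1 to compound 2 (0.30 log units; within the scatter), changes a different group and adds little.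

A fall in the number, somewhat smaller than that guide, is therefore expected, and the estimated change is a 4.5-fold lower number from compound 3 to compound 4 (0.66 log units; beyond the scatter) in this assay as the likely outcome. For compound 4 the estimated value is 15 mL.min-1.g-1 with 6 mL.min-1.g-1 to 40 mL.min-1.g-1 as its expected range.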

Compound 4, intrinsic clearance in microsomes: < 7 mL.min-1.g-1
Compound 4 was reported as a limit; the forecaster's own chance of this, stated with the estimate: 5%; middle value at least 2.1-fold (0.33 log units) away from the limit.
By their numbers in this assay, from the lowest: compounds 2 and 1 (each within the scatter of the next); then compound 3. At a limit, below all of these: compound 4.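

Compound 4 is reported as a limit and not as a number: the limit of < 7 mL.min-1.g-1 in this assay, at which 1 of the 4 values shown sits. In this assay, within the data shown here, the earlier compounds showed only that 4-(methylsulfonyl)piperazin-1-yl at this place goes with a high number, and the new result adds that swapping it for (4-hydroxycyclohexyl)amino, a chain end with a carbon-only ring, brings a large fall, an at least 9.7-fold lower number from compound 3 to compound 4 (0.98 log units; beyond the scatter). The other two steps place compound 4 with the low end of the series: an at least 2.2-fold lower number from compound 1 to compound 4 (0.35 log units; beyond the scatter), which clears the scatter even as a floor, and an at least 1.1-fold lower number from compound 2 to compound 4 (0.05 log units; that floor lies within the scatter), whose floor does not, so for now 4-hydroxycyclohexyl and 2-hydroxy-2-methylpropyl on the amine nitrogen cannot be told apart.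

As far as these compounds go, how far compound 4 really lies under its limit stays open, and with it whether the carbon ring offers anything more than the open chain of compound 2. The compounds shown also leave open which part of the change carries the fall, a question that a plain cyclohexylamino group, without the hydroxyl, or a piperazine lacking the methylsulfonyl group, at the same chain end could address.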